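Cyclohexyl bulk on the urea side chain of compound 1

The source may hold more compounds than are shown below. What is called first, only, known or untested is meant among the compounds shown, and "the series" means these compounds.

Compound 1 `CCCNC(=O)/N=C(\N)NCCCc1sc(N)nc1C` is an aminothiazolyl-propyl acylguanidine carrying a propyl group on its terminal urea nitrogen; in an assay on membranes from Sf9 cells for displacement of a labelled ligand from histamine H2 receptor (Homo sapiens), read by scintillation counting, with a stated time of 60 min (on this read-out lower numbers stand for stronger inhibition and higher numbers for weaker inhibition), compound 1 gives 105 nM, the second highest of the three numbers at hand. Compound 2 `Cc1nc(N)sc1CCCN/C(N)=N/C(=O)N[C@@H](C)c1ccccc1` gives 51.3 nM, and the step of a 2.0-fold lower number from compound 1 to compound 2 (0.31 log units; beyond the scatter) shows that a larger lipophilic substituent on that nitrogen is tolerated. Compound 3 `Cc1nc(N)sc1CCCN/C(N)=N/C(=O)NC(C)c1ccc(OC(F)(F)F)cc1` gives 126 nM, close to compound 1. Compound 4 `Cc1nc(N)sc1CCCN/C(N)=N/C(=O)NCC(C)C1CCCCC1` differs from compound 1 by cyclohexyl in place of hydrogen on a saturated chain carbon bound to two saturated chain carbons. This change resembles the enlargement seen in compound 2, so a similar modest gain is expected. Compound 4 is therefore estimated at 70 nM, with a range from 25 nM to 200 nM, meaning an expected step of a 1.5-fold lower number from compound 1 to compound 4 (0.18 log units; within the scatter).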

Compound 4, inhibition constant: 39.8 nM
The estimate for compound 4 lay 1.8-fold (0.25 log units) above the measured number; measured number inside the range.
By their numbers in this assay, from the lowest: compounds 4 and 2 (each within the scatter of the next); then compounds 1 and 3 (each within the scatter of the next).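

Cyclohexyl in place of hydrogen on a saturated chain carbon bound to two saturated chain carbons gives a 2.6-fold lower number from compound 1 to compound 4 (0.42 log units; beyond the scatter) in this assay, so this side chain accepts a non-aromatic ring of carbon only. Compound 4 and compound 2 lie within the scatter of each other, so this assay does not separate the cyclohexyl-bearing chain from 1-phenylethyl. Nothing at hand explains the step.

The compounds shown leave open whether a piperidine or a carboxylic acid on this carbon would preserve the number. They also leave open how a longer chain carrying the cyclohexyl would read.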